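This account rests on a few compounds, and the source may have more. Where it says the series, first, only, none or still open, it means among the compounds named here.

Measured compounds in an assay on isolated protein for inhibition of Amine oxidase [flavin-containing] B (Homo sapiens), read by fluorescence and spectrophotometry; a lower number here means a stronger inhibitor, a higher number a weaker inhibitor:
compound 1 `O=C(CCCCc1cn(Cc2ccc3oc(-c4ccccc4)cc(=O)c3c2)nn1)Nc1ccccc1` gives 15600 nM
compound 2 `O=C(CCc1cn(Cc2ccc3oc(-c4ccccc4)cc(=O)c3c2)nn1)Nc1ccccc1` gives 15600 nM

In this assay compound 1 stands level with compound 2; the step between them, a shortening of the chain, reads no change at the digits printed from compound 1 to compound 2 (within the scatter). Compound 3 `O=C(CCCCc1cn(Cc2ccc3oc(-c4ccc(Cl)cc4)cc(=O)c3c2)nn1)Nc1ccccc1` keeps the chain of compound 1 and differs only by chloro in place of hydrogen on an aromatic carbon. Among the compounds with values here, the single measured step alters the chain, not the phenyl ring, so it does not bear on this change, and nothing measured here speaks to a chloro on that ring. The expected step from compound 1 to compound 3 is therefore no change at the digits printed from compound 1 to compound 3 (within the scatter), none beyond the scatter. Compound 3 is estimated at 15600 nM, between 5000 nM and 45000 nM.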

Compound 3, half-maximal inhibitory concentration: 32900 nM
Beside the measured number, compound 3's estimate is 2.1-fold (0.32 log units) below it; measured number inside the range.
By their numbers in this assay, from the lowest: compounds 1 and 2 (each within the scatter of the next); then compound 3.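

In this assay, chloro in place of hydrogen on the phenyl ring, para to a large group, gives a 2.1-fold higher number from compound 1 to compound 3 (0.32 log units; beyond the scatter). Within the data shown here, the step is modest, but it is the first here to pass the scatter, so this ring position affects the reading, and chloro there gives a weaker inhibitor. No measurement on hand explains this loss. Going by these compounds, whether a fluoro, a methoxy or an amine in the same place would give a similar step remains open, as does whether chloro would have the same effect on the shorter chain of compound 2.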